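From 4-methoxyphenyl to cyclopropylcarbonyl on the chain

The compounds below may be only part of what the source reports. "The series", "measured", "known", "first", "only" and "open" are said of these compounds alone.

Compound 1 `COc1ccc(-n2c(SCc3ccccc3)nnc2-c2cc(OC)c(OC)c(OC)c2)cc1` gives > 60000 nM (a limit)
Compound 2 `COc1ccc(CSc2nnc(-c3cc(OC)c(OC)c(OC)c3)n2-c2ccc(OC)cc2)cc1` gives > 60000 nM (a limit)
Compound 3 `COc1ccc(-n2c(SCC(=O)c3ccc(F)cc3)nnc2-c2cc(OC)c(OC)c(OC)c2)cc1` gives 42500 nM (a number)

In a functional assay on HT-29 cells (Homo sapiens) for inhibition, read by MTT assay, with a stated time of 48 h (a higher number here means a weaker inhibitor, a lower number a stronger inhibitor), compound 2 stands at > 60000 nM as a limit and not a number. Compound 4 `COc1ccc(-n2c(SCC(=O)C3CC3)nnc2-c2cc(OC)c(OC)c(OC)c2)cc1` differs from it in one place (cyclopropylcarbonyl in place of 4-methoxyphenyl on a saturated chain carbon bound to a sulfur) on the chain. The closest measured change is an at least 1.4-fold lower number from compound 2 to compound 3 (0.14 log units; that floor lies within the scatter) and it also puts a carbonyl at that place, while an at least 1.4-fold lower number from compound 1 to compound 3 (0.14 log units; that floor lies within the scatter) reads the same way. Neither floor goes beyond the scatter, and no size can be taken from a step that the two limits leave unreadable from compound 1 to compound 2 in this case. With an at least 1.4-fold lower number from compound 2 to compound 3 (0.14 log units; that floor lies within the scatter) as the guide, what is expected in this assay is an at least 1.3-fold lower number from compound 2 to compound 4 (0.12 log units; that floor lies within the scatter) toward a lower number, though a limit may be reported again. For compound 4 the estimated value is 45000 nM with 22000 nM to 80000 nM as its expected range.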

Compound 4, half-maximal inhibitory concentration: > 60000 nM
Compound 4 was reported as a limit; the forecaster's own chance of this, stated with the estimate: 35%; middle value at least 1.3-fold (0.12 log units) away from the limit.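

In this assay compound 4 keeps the carbonyl on the chain yet is reported only as a limit, so that carbonyl alone does not give a readable number; among the compounds shown, only compound 3 has one. Cyclopropyl in place of 4-fluorophenyl on a carbonyl carbon gives an at least 1.4-fold higher number from compound 3 to compound 4 (0.14 log units; that floor lies within the scatter). The steps from compound 1 and from compound 2 to compound 4 cannot be read, and the series gathers at one value: the limit of > 60000 nM in this assay, at which 3 of the 4 values shown sit.

Going by these compounds, how far compound 4 lies from that limit stays open. So does whether an amine on the carbonyl carbon, or a longer chain on the sulfur, would give a readable number.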